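The compounds below may be only part of what the source reports. "The series", "measured", "known", "first", "only" and "open" are said of these compounds alone.

Measured compounds:

Compound 1 `O=C(Nc1cc(C(F)(F)F)cc(C(F)(F)F)c1)C1CCc2ccccc2N1C(=O)c1ccccc1Cl` — in a functional assay on HCT-15 cells (Homo sapiens) for cytotoxicity, read by sulforhodamine B assay, with a stated time of 72 h (a higher number here means a weaker inhibitor of growth, a lower number a stronger inhibitor of growth), compound 1 gives 4050 nM.
Compound 2 `CC(=O)N1c2ccccc2CCC1C(=O)Nc1cc(C(F)(F)F)cc(C(F)(F)F)c1` — in this assay compound 2 gives > 70000 nM, which is a limit of the assay rather than a number.
Compound 3 `CCC(=O)N1c2ccccc2CCC1C(=O)Nc1cc(C(F)(F)F)cc(C(F)(F)F)c1` — in this assay compound 3 gives 7620 nM.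

Compound 3 carries the higher of the two numbers obtained, but its gap to compound 1 is small, as a 1.9-fold higher number from compound 1 to compound 3 (0.27 log units; within the scatter) shows, and the remaining value belongs to a limit.

The next compound, compound 4 `O=C(Nc1cc(C(F)(F)F)cc(C(F)(F)F)c1)C1CCc2ccccc2N1`, takes the change (hydrogen in place of propanoyl on a nitrogen on an aromatic ring in a ring). The acyl group on that nitrogen is thus removed altogether.

Two measured steps speak to this. Shortening the acyl group from 2-chlorophenyl to ethyl, a 1.9-fold higher number from compound 1 to compound 3 (0.27 log units; within the scatter), changed little. Shortening further from ethyl to methyl, seen in reverse as an at least 9.1-fold lower number from compound 2 to compound 3 (0.96 log units; beyond the scatter), moved the number past the upper limit of the assay; likewise an at least 17-fold higher number from compound 1 to compound 2 (1.23 log units; beyond the scatter). Among these three compounds, the smaller the group on the carbonyl, the higher the number, with no exception among them.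

Going from propanoyl to a bare hydrogen is a further shortening, so a large increase is expected: the step from compound 3 to compound 4 is estimated as a 7.9-fold higher number from compound 3 to compound 4 (0.90 log units; beyond the scatter). Compound 4 is therefore estimated at 60000 nM, with a likely range from 12000 nM to 300000 nM, and a real chance that only a limit is reported.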

Compound 4, concentration for 50% growth inhibition: 8700 nM
Beside the measured number, compound 4's estimate is 6.9-fold (0.84 log units) above it; measured number outside the range, below it.
By their numbers in this assay, from the lowest: compounds 1, 3 and 4 (each within the scatter of the next, the first and the last beyond it). At a limit, above all of these: compound 2.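

Removing the acyl group altogether leaves the number where it was, with a 1.1-fold higher number from compound 3 to compound 4 (0.06 log units; within the scatter), so in this assay propanoyl and hydrogen on this nitrogen cannot be told apart. The rule that a smaller group on the carbonyl gives a higher number therefore does not extend to hydrogen, as an at least 8.0-fold lower number from compound 2 to compound 4 (0.90 log units; beyond the scatter) shows, and acetyl rather than the bare nitrogen becomes the compound out of line, while a 2.1-fold higher number from compound 1 to compound 4 (0.33 log units; beyond the scatter) leaves the (2-chlorophenyl)carbonyl group as the only substituent here with a modest edge over hydrogen. The value of compound 2 is a limit and not a number, and it is the only one of its kind in this set: the limit of > 70000 nM in this assay, at which 1 of the 4 values shown sits.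

The compounds shown do not tell why acetyl alone stands apart, or whether a longer chain such as butanoyl would follow propanoyl or acetyl. They also leave open whether a plain benzoyl without the chlorine, or an acyl group carrying an amine or a carboxylic acid, would give a lower number than the bare nitrogen does.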